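The compounds below may be only part of what the source reports. "The series", "measured", "known", "first", "only" and "open" are said of these compounds alone.

Three compounds from one series were tested in a functional assay on the whole organism (artery, strain albino) with Rattus norvegicus as the target, with a stated time of 60 min, at a dose of 10 mg/kg by the oral route; a higher number here means more inhibition at the dose given (going by the name of the read-out), a lower number less inhibition. Compound 1 `CC1=C(C(=O)Nc2ccc(Br)cc2)C(c2ccc(Cl)cc2Cl)N=C(SCc2ccc(Cl)cc2)N1` gives 11.8%, compound 2 `CC1=C(C(=O)Nc2ccc(Br)cc2)C(c2ccc(Cl)cc2Cl)N=C(SCc2ccc(F)cc2)N1` gives 16.9%, and compound 3 `CC1=C(C(=O)Nc2ccc([N+](=O)[O-])cc2)C(c2cccc([N+](=O)[O-])c2)N=C(SCc2ccc(Cl)cc2)N1` gives 6.7%. Compound 2 differs from compound 1 by fluoro in place of chloro on an aromatic carbon, and that change brought a number 5.1 percentage points higher from compound 1 to compound 2 (within the scatter). Compound 3 and compound 1 differ in more than one place, and the difference between the two cores is not broken down here. Compound 4 `CC1=C(C(=O)Nc2ccc([N+](=O)[O-])cc2)C(c2cccc([N+](=O)[O-])c2)N=C(SCc2ccc(F)cc2)N1` has not yet been measured; it differs from compound 3 by fluoro in place of chloro on an aromatic carbon, the same change made from compound 1 to compound 2. Resting on the earlier step of a number 5.1 percentage points higher from compound 1 to compound 2 (within the scatter), the expected step is a number 4.3 percentage points higher from compound 3 to compound 4 (within the scatter). In this assay compound 4 is therefore estimated at 11%, with a likely range from 2% to 22%.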

Compound 4, a percentage reported as inhibition, in the whole organism at one dose (the size of the read-out at that dose, not a potency): 7.2%
The estimate for compound 4 lay 3.8 percentage points above the measured number; the range from low to high includes it.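

In this assay, fluoro in place of chloro on the benzyl group gave a number 0.5 percentage points higher from compound 3 to compound 4 (within the scatter). Set beside the earlier step, the change shows no measurable dependence on the core: the same change on two cores in this assay, a number 5.1 percentage points higher (within the scatter) from compound 1 to compound 2 and a number 0.5 percentage points higher (within the scatter) from compound 3 to compound 4, 4.6 percentage points apart, within the scatter of two such steps. For the compounds shown here, this shows only that the two steps cannot be told apart; it does not show that the change has a real effect on either core, since each step lies within the scatter, and two cores cannot speak for the whole series.

The compounds shown leave open whether an amine or a carboxylic acid in place of the halogen would shift the number beyond the scatter. Going by these compounds, whether a longer chain in place of the benzyl group on sulfur would do so also stays open.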